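The compounds below may be only part of what the source reports. "The series", "measured", "known", "first", "only" and "open" are said of these compounds alone.

Three compounds in the series have been run in a functional assay on microsomes for inhibition, read by spectrophotometry, tested at 200 ug/mL; a higher number here means more inhibition at the concentration tested (going by the name of the read-out), a lower number less inhibition. Compound 1 `CCOC(=O)C(C)Oc1ccc(NC(=O)COc2ccccc2C(C)CC)cc1` gives 25% in this assay. Compound 2 `CCOC(=O)C(C)Oc1ccc(NC(=O)COc2ccc3ccccc3c2)cc1` gives 22%, and compound 3 `CCOC(=O)C(C)(C)Oc1ccc(NC(=O)COc2ccc3ccccc3c2)cc1` gives 22%; compound 1 is within the scatter of both, so nothing separates the three numbers. Going by the values given here, the one step measured, no change at the digits printed from compound 2 to compound 3 (within the scatter), lies on the chain carbon and not on the aromatic ring that carries the sec-butyl, so it does not bear on the change to compound 4 `CCOC(=O)C(C)Oc1ccc(NC(=O)COc2ccccc2Cl)cc1`: chloro in place of sec-butyl on an aromatic carbon. Among the compounds with values here, no measured step speaks to this replacement; the three numbers sit close together, and no step beyond the scatter is expected in this assay. Compound 4 is therefore estimated at 23%, with a range of 8% to 40%, the expected step being a number 2 percentage points lower from compound 1 to compound 4 (within the scatter).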

Compound 4, a percentage reported as inhibition, at one concentration (the size of the read-out at that concentration, not a potency): 26%
Estimate against measurement, compound 4: 3 percentage points below; the range from low to high includes it.
By their numbers in this assay, from the lowest: compounds 2, 3, 1 and 4 (each within the scatter of the next).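

In this assay, chloro in place of sec-butyl on an aromatic carbon, ortho to a large group, gives a number 1 percentage points higher from compound 1 to compound 4 (within the scatter) and so lies within the scatter. Going by these compounds alone, at this position, then, going from 4 heavy atoms to 1 heavy atom does not separate the two readings, the first measured evidence on this ring. Nothing available gives a reason for this result.

On these data alone, whether an amine, a carboxylic acid or a longer chain on this aromatic carbon would move the reading beyond the scatter remains open. Also open, as far as these compounds go, is whether chloro reads the same on the core of compound 3.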